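The source may report more compounds than this note shows. Statements on the series, on what has been measured and on what is new or still open speak of the compounds shown alone.

Compound 1 `CCC1=C(C(=O)OCC2CCCCC2)C(c2cccc(O)c2)NC(=O)N1`: > 10000 nM
Compound 2 `O=C1NC(CCl)=C(C(=O)OCC2CCCCC2)C(c2cccc(O)c2)N1`: > 3000 nM

Both entries come from an ADME assay on CEMx174 cells (Homo sapiens) for cytotoxicity (a lower number here means that less compound is tolerated, a higher number that more compound is tolerated), and neither is a number. Compound 1 gives only a limit, > 10000 nM. As far as these compounds go, compound 2 also gives only a limit, > 3000 nM, so its true position remains unknown.

Compound 3 `C#CC1=C(C(=O)OCC2CCCCC2)C(c2cccc(O)c2)NC(=O)N1` keeps the shared core of compound 2 and has ethynyl in place of chloromethyl on a double-bonded ring carbon.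

Going by the values given here, the only measured step that bears on this change is a step that the two limits leave unreadable from compound 1 to compound 2. It offers no size to carry over, and it concerns a different replacement at the same ring carbon. With nothing to suggest a real shift in this assay, the expected change is a step that the limit leaves unreadable from compound 2 to compound 3, with no step beyond the scatter and no favoured direction. For compound 3, the estimated value is 5000 nM, with an expected range of 1500 nM to 20000 nM.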

Compound 3, half-maximal cytotoxic concentration: > 1000 nM
Compound 3: a limit, no number; the forecaster's own chance of this, stated with the estimate: 70%; the middle value is on the limit's open side.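

In this assay, going by these compounds alone, compound 3 gives only a limit, > 1000 nM, so no step among compound 1, compound 2 and compound 3 can be read. The compounds shown leave open where each truly stands, and whether ethyl, chloromethyl or ethynyl on the double-bonded ring carbon makes any difference.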